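A few compounds are considered here, and "the series" means these few. Any claim that something is new, unique, unknown or untested is made for them only; others in the source may bear on it.

For the measured compounds named here, compound 1 `O=C(Nc1ccc(Oc2ccnc3[nH]ccc23)cc1)c1cc2cccnc2n(-c2ccc(Cl)cc2)c1=O` is the only member of this small set with a number: in a functional assay on NCI-H460 cells (Homo sapiens) for antiproliferative activity, read by MTT assay, with a stated time of 72 h (a lower number here means a stronger inhibitor, a higher number a weaker inhibitor), compound 1 gives 290 nM. Compound 2 `O=C(Nc1ccc(Oc2ccnc3[nH]ccc23)cc1)c1cc2cccnc2n(-c2ccc(Br)cc2F)c1=O` has in this assay only the entry "not determined" (no result reported), and compound 3 `Cn1ccc2c(Oc3ccc(NC(=O)c4cc5cccnc5n(-c5ccc(Cl)cc5)c4=O)cc3)ccnc21` likewise stands there with the entry "not determined" (no result reported), so where compound 3 sits can only be guessed from the value of compound 1. Compound 4 `Cn1ccc2c(Oc3ccc(NC(=O)c4cc5cccnc5n(-c5ccc(C(F)(F)F)cc5Cl)c4=O)cc3)ccnc21` differs from compound 3 by 2-chloro-4-(trifluoromethyl)phenyl in place of 4-chlorophenyl on an aromatic nitrogen. Going by the values given here, no measured step covers this change, so no direction can be drawn from the data; the move is expected to alter this assay by no more than the usual scatter, in either direction. Compound 4 is therefore expected to give about 250 nM in this assay, within a range from 60 nM to 1000 nM.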

Compound 4, half-maximal inhibitory concentration: 6950 nM
Compound 4: middle estimate off by 28-fold (1.44 log units), on the low side; measured number above the stated range.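

The step from compound 3 to compound 4 cannot be read, as compound 3 has no single number in this assay. The compounds shown leave open what 2-chloro-4-(trifluoromethyl)phenyl in place of 4-chlorophenyl does on its own. No evidence given here bears on this result.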